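The source may hold more compounds than are shown below. What is called first, only, known or untested is meant among the compounds shown, and "the series" means these compounds.

Going by the values given here, in a functional assay on THP-1 cells (Homo sapiens) for cytotoxicity, read by MTT assay, with a stated time of 24 h (a higher number here means a weaker inhibitor, a lower number a stronger inhibitor), compound 1 (`COc1cc(/C=C2\CN(C)C/C(=C\c3ccc(F)cc3)C2=O)cc(OC)c1`) gives 5040 nM and compound 2 (`COc1cc(/C=C2\CN(C)C/C(=C\c3ccc(Cl)cc3Cl)C2=O)cc(OC)c1`) gives 6070 nM and so stands within the scatter of compound 1, the only other compound measured. Compound 3 (`COc1cc(/C=C2\CN(C)C/C(=C\c3ccc(C#N)cc3)C2=O)cc(OC)c1`) has 4-cyanophenyl in place of 2,4-dichlorophenyl on a double-bonded chain carbon bound to a double-bonded ring carbon. Among the compounds with values here, the one measured step at this place (a 1.2-fold higher number from compound 1 to compound 2 (0.08 log units; within the scatter)) lies within the scatter, so no step beyond the scatter is expected in this assay for this change. The expected step is small (a 1.3-fold lower number from compound 2 to compound 3 (0.13 log units; within the scatter)). The estimated value for compound 3 is 4500 nM with 1800 nM to 10000 nM as its expected range.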

Compound 3, half-maximal inhibitory concentration: 940 nM
Compound 3: middle estimate off by 4.8-fold (0.68 log units), on the high side; the whole stated range lies above it.
By their numbers in this assay, from the lowest: compound 3; then compounds 1 and 2 (each within the scatter of the next).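

In this assay the place on a double-bonded chain carbon bound to a double-bonded ring carbon proves sensitive to its group, which compound 1 and compound 2 had not shown: the change to 4-cyanophenyl gives a 6.5-fold lower number from compound 2 to compound 3 (0.81 log units; beyond the scatter) and cyano in place of fluoro on an aromatic carbon gives a 5.4-fold lower number from compound 1 to compound 3 (0.73 log units; beyond the scatter) in the same direction. Nothing available accounts for these steps. Open, as far as these compounds go, is whether the nitrile itself is needed, or whether a nitro group, a carboxylic acid or an amine on the same phenyl ring would give a similar number.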